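Removing the trifluoromethyl group from compound 2

This account rests on a few compounds, and the source may have more. Where it says the series, first, only, none or still open, it means among the compounds named here.

In a functional assay on OE19 cells (Homo sapiens) for cytotoxicity, read by MTT assay, with a stated time of 48 h (on this read-out lower numbers stand for stronger inhibition and higher numbers for weaker inhibition), compound 2, `CC1(C)S[C@@H]2/C(=C\C(=O)c3ccc(C(F)(F)F)cc3)C(=O)N2[C@H]1C(=O)OC(c1ccccc1)c1ccccc1`, gives 15600 nM, the lowest of the two numbers in the set. Compound 3, `CC1(C)[C@H](C(=O)OC(c2ccccc2)c2ccccc2)N2C(=O)/C(=C/C(=O)c3ccccc3)[C@H]2S1(=O)=O`, gives 53100 nM in this assay, which is beyond the scatter from the value of compound 2. Compound 1, `CC(=O)/C=C1\C[C@H]2SC(C)(C)[C@H](C(=O)OC(c3ccccc3)c3ccccc3)N2C1=O`, reaches only a limit of this assay, > 100000 nM, so no number stands for it; this is the limit described by the limit of > 100000 nM in this assay, at which 1 of the 3 values shown sits.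

Compound 4, `CC1(C)S[C@@H]2/C(=C\C(=O)c3ccccc3)C(=O)N2[C@H]1C(=O)OC(c1ccccc1)c1ccccc1`, has not yet been measured in this assay. It differs from compound 2 in one place: hydrogen in place of trifluoromethyl on an aromatic carbon of a six-membered aromatic ring of carbon only, para to a large group. Among the compounds with values here, no pair of measured compounds shows this change alone, so the size of the step is not known from the set.

Compound 4 is expected to show a weaker inhibition than compound 2, with a step of a 1.9-fold higher number from compound 2 to compound 4 (0.28 log units; within the scatter) that lies near the edge of the scatter. The estimate for compound 4 in this assay is 30000 nM, within a range from 8000 nM to 100000 nM.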

Compound 4, half-maximal inhibitory concentration: 12800 nM
Compound 4: the middle estimate sits 2.3-fold (0.37 log units) above what was measured; measured number inside the range.
By their numbers in this assay, from the lowest: compounds 4 and 2 (each within the scatter of the next); then compound 3. At a limit, above all of these: compound 1.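

Within the data shown here, the first measured change at this position is small: hydrogen in place of trifluoromethyl on an aromatic carbon, para to a large group, gives a 1.2-fold lower number from compound 2 to compound 4 (0.09 log units; within the scatter) in this assay, so compound 2 and compound 4 cannot be told apart on this read-out. Among these compounds, until now the set held no pair that isolated this position, and this pair shows that 4-(trifluoromethyl)phenyl and phenyl are interchangeable here, at least at this level of cytotoxicity, with compound 4 keeping the full level of compound 2 without any fluorine atom in the molecule. The values shown offer no measured property that would explain why the two compounds match, and none of them bears on this step.

The compounds shown leave open whether a different group on this aromatic carbon, such as an amine, a methoxy group or a carboxylic acid, would move the number beyond the scatter, or whether this position tolerates nearly any replacement. They also leave open whether the same exchange would stay this small on the core of compound 1 or of compound 3.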